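This account rests on a few compounds, and the source may have more. Where it says the series, first, only, none or still open, it means among the compounds named here.

In a functional assay on KB 3-1 cells (Homo sapiens), with a stated time of 72 h (a higher number here means a weaker inhibitor, a lower number a stronger inhibitor), compound 1 `C[C@H]1CCC[C@@]2(C)O[C@H]2C[C@@H](c2ccc3c(c2)ncn3C)OC(=O)C[C@H](O)C(C)(C)C(=O)[C@H](C)[C@H]1O` gives 0.13 nM, and compound 2 `C[C@H]1CCC[C@@]2(C)O[C@H]2C[C@@H](c2ccc3cccnc3c2)OC(=O)C[C@H](O)C(C)(C)C(=O)[C@H](C)[C@H]1O` gives 0.11 nM. For the measured compounds named here, these two values lie within the scatter of each other, so compound 2 stands level with compound 1 on the numbers so far.

The next compound is compound 3 `C/C(=C\c1ccccn1)[C@@H]1C[C@@H]2O[C@]2(C)CCC[C@H](C)[C@H](O)[C@@H](C)C(=O)C(C)(C)[C@@H](O)CC(=O)O1`, with the change (a group of 9 heavy atoms (8 carbon, 1 nitrogen; one six-membered aromatic ring with 1 hetero atom) in place of a group of 10 heavy atoms (9 carbon, 1 nitrogen; one six-membered aromatic ring of carbon only, one six-membered aromatic ring with 1 hetero atom), on a saturated ring carbon). The change sits on a saturated ring carbon next to the ring oxygen. Quinolin-7-yl leaves, and the group that enters has a double bond outside aromatic rings.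

Going by the values given here, only one measured step bears on this: a 1.2-fold lower number from compound 1 to compound 2 (0.07 log units; within the scatter), with quinolin-7-yl in place of 1-methyl-1H-benzimidazol-5-yl on the same ring carbon. That step stays within the scatter, but it is only a weak guide. Among the compounds with values here, no measured compound carries a group with a double bond outside aromatic rings at this carbon, and none has lost the six-membered aromatic ring of carbon only.

A modest rise in the number is therefore expected in this assay, estimated as a 2.7-fold higher number from compound 2 to compound 3 (0.44 log units; beyond the scatter). The estimate for compound 3 is 0.3 nM, with an expected range from 0.1 nM to 0.9 nM.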

Compound 3, half-maximal inhibitory concentration: 0.3 nM
Compound 3: middle estimate and measured number agree at the digits printed, within the range that was stated.
By their numbers in this assay, from the lowest: compounds 2 and 1 (each within the scatter of the next); then compound 3.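

In this assay, the saturated ring carbon next to the ring oxygen now shows a step beyond the scatter: the group with one six-membered aromatic ring with 1 hetero atom and 1 double bond outside aromatic rings, in place of quinolin-7-yl, gives a 2.7-fold higher number from compound 2 to compound 3 (0.44 log units; beyond the scatter), and in place of 1-methyl-1H-benzimidazol-5-yl it gives a 2.3-fold higher number from compound 1 to compound 3 (0.36 log units; beyond the scatter). The two groups with fused aromatic rings had stood within the scatter of each other, so the earlier pair showed no sensitivity at this carbon, while these steps show that the number does respond to the group placed there, though both steps are only modest. No supporting measurement bears on the reason for this rise.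

From the compounds shown here alone, compound 3 differs from compound 2 both in the loss of the six-membered aromatic ring of carbon only and in the gain of the double bond outside aromatic rings, so the share of each in the step remains open. Also open, going by these compounds, is how the number would respond at this carbon to a group of another kind, such as a thiazole ring joined through the same double bond or a pyridine ring carrying an aminomethyl group.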